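The compounds below may be only part of what the source reports. "The series", "measured", "known", "first", "only" and "open" are said of these compounds alone.

Measured compounds:
compound 1 `COc1cc(/C=C2\CN(C)C/C(=C\c3ccc(Cl)cc3Cl)C2=O)cc(OC)c1` gives 6250 nM in a functional assay on HepG2 cells (Homo sapiens) for cytotoxicity, read by MTT assay, with a stated time of 24 h; on this read-out lower numbers stand for stronger inhibition and higher numbers for weaker inhibition;
compound 2 `COc1cc(/C=C2\CN(C)C/C(=C\c3ccc(Cl)c(Cl)c3)C2=O)cc(OC)c1` gives 3840 nM in this assay;
compound 3 `CN1C/C(=C\c2cccc([N+](=O)[O-])c2)C(=O)/C(=C/c2ccc(Cl)cc2Cl)C1` gives 4800 nM in this assay.

Compound 1 and compound 2 differ in one place, (3,4-dichlorophenyl in place of 2,4-dichlorophenyl on a double-bonded chain carbon bound to a double-bonded ring carbon), and this change gave a 1.6-fold lower number from compound 1 to compound 2 (0.21 log units; within the scatter). Compound 3 carries another core; the difference between the core of compound 3 and the core of compound 1 is not broken down here, and its value sits within the scatter of both compound 1 and compound 2.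

Compound 4 `CN1C/C(=C\c2cccc([N+](=O)[O-])c2)C(=O)/C(=C/c2ccc(Cl)c(Cl)c2)C1` applies the same change to the core of compound 3: 3,4-dichlorophenyl in place of 2,4-dichlorophenyl on a double-bonded chain carbon bound to a double-bonded ring carbon. Since the place of the change is the same in both pairs, compound 4 is expected to move from compound 3 by about a 1.4-fold lower number from compound 3 to compound 4 (0.14 log units; within the scatter), a step resting on a 1.6-fold lower number from compound 1 to compound 2 (0.21 log units; within the scatter). Compound 4 is therefore estimated at 3500 nM in this assay, likely between 1600 nM and 7500 nM.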

Compound 4, half-maximal inhibitory concentration: 5960 nM
The estimate for compound 4 lay 1.7-fold (0.23 log units) below the measured number; measured number inside the range.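

In this assay, 3,4-dichlorophenyl in place of 2,4-dichlorophenyl on the core of compound 3 gave a 1.2-fold higher number from compound 3 to compound 4 (0.09 log units; within the scatter). Set beside the earlier step, this one shows no real difference between the two cores: the same change on two cores in this assay, a 1.6-fold lower number (0.21 log units; within the scatter) from compound 1 to compound 2 and a 1.2-fold higher number (0.09 log units; within the scatter) from compound 3 to compound 4, 2.0-fold (0.31 log units) apart, within the scatter of two such steps The change therefore carried from one core to the other without a measurable dependence on the core, but since each step lies within the scatter, the pair shows no effect of the change on either core and cannot establish that one would transfer.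

Going by these compounds, it remains open whether a phenyl carrying an amine or a carboxylic acid in place of either dichlorophenyl group would give a step beyond the scatter. On these data alone, whether the same holds on further cores also stays open.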